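Moving Two Fluorines on a Benzyl Ether: Vero Cytotoxicity

The source may hold more compounds than are shown below. What is called first, only, known or untested is meant among the compounds shown, and "the series" means these compounds.

Compound 1, `CCOC(=O)c1cc(-c2cccc(OCc3ccccc3Cl)c2)on1`: > 128000 nM
Compound 2, `CCOC(=O)c1cc(-c2cccc(OCc3cccc(F)c3F)c2)on1`: > 128000 nM

Of the compounds shown here, two have been tested in an ADME assay on Vero cells (Chlorocebus sabaeus) for cytotoxicity, with a stated time of 72 h; a lower number here means a stronger inhibitor, a higher number a weaker inhibitor. Compound 1 reaches only the limit of the test, > 128000 nM. Compound 2 likewise reaches only the limit, > 128000 nM. So compound 2 stands at the cut-off where both measured readings sit, (the limit of > 128000 nM in this assay, at which 2 of the 2 values shown sit), and no actual number is known for it. Within the data shown here, the one recorded change, a step that the two limits leave unreadable from compound 1 to compound 2, replaced one aryl group with another on the saturated chain carbon bound to the ring oxygen and left the reading at the limit at both ends, so its size is not known.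

Compound 3, `CCOC(=O)c1cc(-c2cccc(OCc3ccc(F)c(F)c3)c2)on1`, is not yet measured. It differs from compound 2 by 3,4-difluorophenyl in place of 2,3-difluorophenyl on a saturated chain carbon bound to an oxygen on an aromatic ring. Among the measured compounds shown here, the only measured step bears on it, in that it also moved substituents around a phenyl ring at this place, and it showed no readable movement at all. The expectation in this assay is therefore no step beyond the scatter, most likely another reading at the limit. Compound 3 is estimated at 200000 nM, between 100000 nM and 400000 nM, which means an expected step that the limit leaves unreadable from compound 2 to compound 3.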

Compound 3, half-maximal inhibitory concentration: > 128000 nM
Compound 3: no number, only a limit; the forecaster's own chance of this, stated with the estimate: 85%; the middle value is on the limit's open side.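

In this assay compound 3 gives only a limit, > 128000 nM. No step among compound 1, compound 2 and compound 3 can be read, as all three sit at one cut-off: the limit of > 128000 nM in this assay, at which 3 of the 3 values shown sit.

Still open, from the compounds shown here alone, is where the true value of each compound lies, and whether changing the aryl group on the saturated chain carbon alters cytotoxicity at all.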